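Swapping a trifluoromethyl for isopropyl on the pendant ring

The compounds below may be only part of what the source reports. "The series", "measured", "known", "first", "only" and "open" are said of these compounds alone.

The series rests on a shared core carrying a methylamide-bearing benzylic arm and a two-carbon chain to a substituted phenyl ring. Compound 1 `CCn1nc(C)c2c1CCN([C@@H](C(=O)NC)c1ccccc1)[C@H]2CCc1ccc(C(F)(F)F)cc1` was tested in a functional assay on CHO cells for antagonist activity at Orexin receptor type 2 (Homo sapiens), read by FLIPR and calcium flux (on this read-out lower numbers stand for stronger inhibition and higher numbers for weaker inhibition), and gives 3 nM. Its companion, compound 2 `CCn1nc(C)c2c1CCN(C(C(=O)NC)c1ccccc1)C2CCc1ccc(C)cc1`, carries a methyl in place of the trifluoromethyl on that ring; in this assay compound 2 gives 6 nM. Of the two numbers, compound 1 has the lower one, but the gap to compound 2 lies within the usual scatter, so the two cannot be ranked against each other.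

The untested compound 3 `CCn1nc(C)c2c1CCN([C@@H](C(=O)NC)c1ccccc1)[C@H]2CCc1ccc(C(C)C)cc1` differs from compound 1 by a single change: isopropyl in place of trifluoromethyl on an aromatic carbon. For the measured compounds named here, no measured pair shows this exact change, so there is no measured step to lean on. Since compound 2, with a methyl at the same place, gives 6 nM, a small alkyl there appears to be tolerated. Compound 3 is therefore expected to sit close to compound 1, with a step from compound 1 to compound 3 of about a 1.7-fold higher number from compound 1 to compound 3 (0.22 log units; within the scatter), not beyond the scatter. The estimate for compound 3 in this assay is 5 nM, with a range from 2 nM to 15 nM.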

Compound 3, half-maximal inhibitory concentration: 9 nM
Compound 3: middle estimate off by 1.8-fold (0.26 log units), on the low side; the measured number falls inside the stated range.
By their numbers in this assay, from the lowest: compounds 1, 2 and 3 (each within the scatter of the next, the first and the last beyond it).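

In this assay, for the compounds shown here, isopropyl in place of trifluoromethyl on this aromatic carbon gives a 3.0-fold higher number from compound 1 to compound 3 (0.48 log units; beyond the scatter) and is the first measured step at this position that lies beyond the usual scatter. The earlier pair could not be ranked, and it also differed in how its stereochemistry was drawn, whereas this change alone shows that the group at this place can shift the number, if only modestly, with compound 3 still at 9 nM in this read-out. Nothing available accounts for the step, so it stands as an observation without an explanation.

The compounds shown leave open how a chlorine, a methoxy or a tert-butyl at the same aromatic carbon would read, and whether an amine or a carboxylic acid would be accepted there at all. They also leave open whether the same swap gives a similar step on a different arm of the shared core, or for the opposite stereoisomer of compound 1.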